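Methoxy on the Fused Ring of a Hydroxamic Acid Chalcone

The source may hold more compounds than are shown below. What is called first, only, known or untested is meant among the compounds shown, and "the series" means these compounds.

Within the data shown here, compound 1 `O=C(/C=C/c1ccc(/C=C/C(=O)c2ccc3ccccc3c2)o1)NO` is the weaker of the two measured members: in a functional assay on HCT-116 cells (Homo sapiens) for antiproliferative activity, read by MTT assay, with a stated time of 48 h (on this read-out higher numbers stand for weaker inhibition and lower numbers for stronger inhibition), compound 1 gives 2220 nM. Compound 2 `CC(C)c1ccc(C(=O)/C=C/c2ccc(/C=C/C(=O)NO)o2)cc1` gives 490 nM in this assay, a lower number than compound 1 by a gap beyond the usual scatter, so compound 1 stands at the top of the numbers seen so far. Compound 3 `COc1ccc2cc(C(=O)/C=C/c3ccc(/C=C/C(=O)NO)o3)ccc2c1` has not been measured. Compound 3 differs from compound 1 by methoxy in place of hydrogen on an aromatic carbon. Among the measured compounds shown here, no measured pair shows this change directly, and the two measured values offer no guide to it; the expectation for compound 3 is therefore a small step downward from compound 1, a 1.6-fold lower number from compound 1 to compound 3 (0.20 log units; within the scatter), which may well stay within the scatter. Compound 3 is estimated at 1400 nM in this assay, with a range from 500 nM to 4000 nM.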

Compound 3, half-maximal inhibitory concentration: 2060 nM
For compound 3 the middle estimate is 1.5-fold (0.17 log units) below the measured one, within the range that was stated.
By their numbers in this assay, from the lowest: compound 2; then compounds 3 and 1 (each within the scatter of the next).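

In this assay, among these compounds, the step for methoxy in place of hydrogen on an aromatic carbon is a 1.1-fold lower number from compound 1 to compound 3 (0.03 log units; within the scatter), the first direct reading of this change. At this position, meta to a fused ring and para to a fused ring on the six-membered aromatic ring of carbon only, the methoxy group is tolerated without a change that can be told from the scatter, so one added oxygen and one added carbon leave the read-out where it stood. Nothing available explains this outcome.

One substituent at one position cannot show whether the read-out stays unmoved for other groups, such as an amine, a carboxylic acid or a longer alkoxy chain. The same methoxy group on another carbon of the fused system also remains an open question.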